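Hydrazine substituent at the thiadiazole amine: cyclopentyl to phenyl

The source may hold more compounds than are shown below. What is called first, only, known or untested is meant among the compounds shown, and "the series" means these compounds.

Compound 1, `CC(C)NNc1nnc(-c2ccccc2Cl)s1`: 50 mg/kg.
Compound 2, `Clc1ccccc1-c1nnc(NNC2CCCC2)s1`: > 100 mg/kg.
Compound 3, `Clc1ccccc1-c1nnc(NNc2ccccc2)s1`: not yet measured.

In a functional assay on the whole organism with Mus musculus as the target, in the maximal electroshock model, with a stated time of 1 h (on this read-out lower numbers stand for an effect already at smaller amounts and higher numbers for an effect only at larger amounts of compound), compound 1 gives 50 mg/kg. For compound 2 the read-out of > 100 mg/kg is a limit of the assay, not a number; compound 2 therefore stands at the top end of the numbers shown, with the limit of > 100 mg/kg in this assay, at which 1 of the 2 values shown sits, marking where it sits. Among the compounds with values here, the step of an at least 2.0-fold higher number from compound 1 to compound 2 (0.30 log units; that floor lies within the scatter) is the only measured step.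

Compound 3 differs from compound 2 by phenyl in place of cyclopentyl on an amine nitrogen. Within the data shown here, no measured step exchanges a saturated ring for an aromatic one at this nitrogen; the only step on record, an at least 2.0-fold higher number from compound 1 to compound 2 (0.30 log units; that floor lies within the scatter), changes the same position but from a smaller alkyl group to the cyclopentyl group, and its floor lies within the scatter. The data give no direction for an aromatic group here, so no step beyond the scatter is expected in this assay from compound 2 to compound 3, and the estimate carries wide bounds.

Compound 3 is expected at 100 mg/kg in this assay, with a range from 40 mg/kg to 300 mg/kg, meaning an estimated step of a number no higher from compound 2 to compound 3 (the limit leaves the size open).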

Compound 3, dose for half-maximal effect: > 100 mg/kg
Compound 3: only a limit was reported; the forecaster's own chance of this, stated with the estimate: 50%; the middle value sits exactly at the limit.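

In this assay compound 3 gives > 100 mg/kg, a limit of the assay and not a number. Phenyl in place of isopropyl on the amine nitrogen gives an at least 2.0-fold higher number from compound 1 to compound 3 (0.30 log units; that floor lies within the scatter), so this change, like the change to cyclopentyl, has only a floor that does not pass beyond the scatter. The step between the two ring compounds cannot be read, but the series now shows that a six-membered aromatic ring of carbon and a five-membered non-aromatic ring of carbon at this nitrogen end at the same reported limit: the limit of > 100 mg/kg in this assay, at which 2 of the 3 values shown sit.

From the compounds shown here alone, how far compound 2 and compound 3 lie past that limit stays open, so these floors settle neither whether the isopropyl group of compound 1 differs from either ring group beyond the scatter nor whether the two ring groups differ from each other. Also open, going by these compounds, is whether a methyl group, an ethyl group or a benzyl group on this nitrogen would give a true number rather than a limit in this assay, and so show whether the read-out at this position follows the size of the group or the presence of a ring.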